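A Bromophenyl Replaces a Methylphenyl: Expected Cytotoxicity

The source may hold more compounds than are shown below. What is called first, only, known or untested is meant among the compounds shown, and "the series" means these compounds.

Measured in a functional assay on MCF7 cells (Homo sapiens) for cytotoxicity, read by MTT assay, with a stated time of 72 h; on this read-out higher numbers stand for weaker inhibition and lower numbers for stronger inhibition:
Compound 1 `FC(F)(F)c1ccc(CSc2nc(Nc3ccccc3)c3ccccc3n2)cc1` gives 44000 nM.
Compound 2 `COc1ccccc1Nc1nc(SCc2ccc(C(F)(F)F)cc2)nc2ccccc12` reaches only a limit of this assay, > 50000 nM.
Compound 3 `Cc1ccccc1Nc1nc(SCc2ccc(C(F)(F)F)cc2)nc2ccccc12` gives 37500 nM.

Among the two numbers, compound 3 has the lowest, with compound 1 nearest (a 1.2-fold lower number from compound 1 to compound 3 (0.07 log units; within the scatter)). Compound 2 sits at the limit of > 50000 nM in this assay, at which 1 of the 3 values shown sits (an at least 1.1-fold higher number from compound 1 to compound 2 (0.05 log units; that floor lies within the scatter); an at least 1.3-fold lower number from compound 2 to compound 3 (0.12 log units; that floor lies within the scatter)). Compound 4 `FC(F)(F)c1ccc(CSc2nc(Nc3cccc(Br)c3)c3ccccc3n2)cc1` carries 3-bromophenyl in place of 2-methylphenyl on a nitrogen on an aromatic ring. Going by the values given here, no measured pair involves a bromine; the steps that vary this ring all stay within the scatter. The step from compound 3 to compound 4 is therefore expected to be small in this assay, about a 1.1-fold higher number from compound 3 to compound 4 (0.03 log units; within the scatter). Compound 4 is estimated at 40000 nM, within 15000 nM to 90000 nM.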

Compound 4, half-maximal inhibitory concentration: 25600 nM
For compound 4 the middle estimate is 1.6-fold (0.19 log units) above the measured one, within the range that was stated.
By their numbers in this assay, from the lowest: compounds 4, 3 and 1 (each within the scatter of the next). At a limit, above all of these: compound 2.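

Bromine now appears on the ring carried by this nitrogen, and the 3-bromophenyl compound stays within the scatter of both compounds with a measured number (a 1.5-fold lower number from compound 3 to compound 4 (0.17 log units; within the scatter); a 1.7-fold lower number from compound 1 to compound 4 (0.24 log units; within the scatter)). Against compound 2 only a floor can be read (an at least 1.9-fold lower number from compound 2 to compound 4 (0.29 log units; that floor lies within the scatter)). That compound is held at a limit, not a number: the limit of > 50000 nM in this assay, at which 1 of the 4 values shown sits. On these data alone, whether a carboxylic acid or an amine on this ring, or a 2-bromophenyl in place of the 3-bromophenyl, would give a step beyond the scatter remains open.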